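The compounds below may be only part of what the source reports. "The series", "measured", "known", "first", "only" and "open" are said of these compounds alone.

Measured compounds:
compound 1 `O=C(NC1CCCC1)c1[nH]cnc1-c1nc2ccccc2[nH]1`, 20600 nM
compound 2 `O=C(NC1CCCCC1)c1[nH]cnc1-c1nc2ccccc2[nH]1`, 8300 nM

In a functional assay on MDA-MB-231 cells (Homo sapiens) for inhibition, read by MTT assay, with a stated time of 48 h (on this read-out higher numbers stand for weaker inhibition and lower numbers for stronger inhibition), compound 1 gives 20600 nM and compound 2 gives 8300 nM. Among the compounds with values here, the single measured step, a 2.5-fold lower number from compound 1 to compound 2 (0.39 log units; beyond the scatter), is a modest change on the amide nitrogen. Compound 2 therefore stands lowest of the two numbers, with compound 1 the nearest and higher.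

Compound 3 `Cn1c(-c2nc[nH]c2C(=O)NC2CCCCC2)nc2ccccc21` differs from compound 2 by methyl in place of hydrogen on an aromatic nitrogen. Within the data shown here, no measured step touches this aromatic nitrogen: the one step recorded concerns the amide nitrogen only, so there is nothing that speaks for or against a change in this assay here. With no bearing evidence, the expectation is a step of about a 1.2-fold higher number from compound 2 to compound 3 (0.08 log units; within the scatter), which is not beyond the scatter. As far as these compounds go, compound 3 is accordingly estimated at 10000 nM, within a range of 3000 nM to 35000 nM, the width reflecting that the effect of this change is untested.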

Compound 3, half-maximal inhibitory concentration: 36800 nM
For compound 3 the middle estimate is 3.7-fold (0.57 log units) below the measured one; the whole stated range lies below it.
By their numbers in this assay, from the lowest: compound 2; then compounds 1 and 3 (each within the scatter of the next).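

In this assay the step of a 4.4-fold higher number from compound 2 to compound 3 (0.65 log units; beyond the scatter) shows that this aromatic nitrogen, on the five-membered aromatic ring and next to the ring atom that bears a large group, is not a silent position. The earlier compounds shown here varied only the amide nitrogen, whereas here a single methyl in place of hydrogen moves the read-out towards weaker inhibition, with the cyclohexyl amide unchanged. No measurement at hand accounts for this shift, so it stands as an observation only. 

As far as these compounds go, whether an ethyl or a benzyl group on this nitrogen would give a similar step remains open. Also open, from the compounds shown here alone, is whether the same methyl would act in the same direction on compound 1, with its cyclopentyl group, or on an amide carrying an amine or a carboxylic acid.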